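A few compounds are considered here, and "the series" means these few. Any claim that something is new, unique, unknown or untested is made for them only; others in the source may bear on it.

The measured compounds, each with its structure and its value:

Compound 1 `O=C1C(Nc2cccc(Cl)c2)=CC(=O)c2c1nc1n2[C@H]2OC[C@@H](O)[C@H]2OC1` — in a functional assay on MCF7 cells (Homo sapiens) for inhibition, read by sulforhodamine B assay (on this read-out higher numbers stand for weaker inhibition and lower numbers for stronger inhibition), compound 1 gives 2970 nM.
Compound 3 `O=C1C=C(Nc2cccc(Cl)c2)C(=O)c2c1nc1n2[C@H]2OC[C@@H](O)[C@H]2OC1` — in this assay compound 3 gives 4720 nM.
Compound 2 `O=C1C=C(NCc2ccccc2)C(=O)c2c1nc1n2[C@H]2OC[C@@H](O)[C@H]2OC1` — in this assay compound 2 reaches only a limit of the assay, > 8000 nM.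

Compound 1 holds the lowest of the two numbers given, but the gap to compound 3 is within the usual scatter, so the two cannot be ranked against each other. Compound 2 is known only by its limit, (the limit of > 8000 nM in this assay, at which 1 of the 3 values shown sits).

One measured step exists: an at least 1.6-fold lower number from compound 2 to compound 3 (0.22 log units; that floor lies within the scatter). It swaps a benzyl group for a 3-chlorophenyl group and says nothing about exchanging one substituent on an aromatic ring for another, which is the change now at hand.

Compound 4 `CCc1ccc(NC2=CC(=O)c3c(nc4n3[C@H]3OC[C@@H](O)[C@H]3OC4)C2=O)cc1` differs from compound 1 by 4-ethylphenyl in place of 3-chlorophenyl on an amine nitrogen. Among the measured pairs there is none in which one aryl group is replaced by another aryl group on the amine nitrogen, so there is no measured step to lean on. The expectation is therefore that the number stays close to that of compound 1, with no step beyond the scatter: a 1.2-fold higher number from compound 1 to compound 4 (0.07 log units; within the scatter). Compound 4 is estimated at 3500 nM, in this assay, with a range from 1200 nM to 10000 nM.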

Compound 4, half-maximal inhibitory concentration: 8990 nM
Estimate against measurement, compound 4: 2.6-fold (0.41 log units) below, within the range that was stated.
By their numbers in this assay, from the lowest: compounds 1, 3 and 4 (each within the scatter of the next, the first and the last beyond it).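

Exchanging one aryl group for another on this amine nitrogen makes a measurable difference in this assay: the change gives a 3.0-fold higher number from compound 1 to compound 4 (0.48 log units; beyond the scatter). The earlier compounds shown here offered no such comparison, and this one shows that the aryl group at this place cannot be swapped freely, since compound 4 inhibits more weakly than compound 1, though only modestly so. None of the information shown gives a reason for this difference.

The swap changes two things at once, the substituent itself (chlorine gives way to ethyl) and the number in the group's name (3 becomes 4), so the compounds shown leave open which of the two accounts for the step. They also leave open how the shared core responds when the ring on this nitrogen is a plain phenyl or carries a methoxy group, a carboxylic acid or an amine, so a single pair cannot yet show a trend for this position.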